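The source may report more compounds than this note shows. Statements on the series, on what has been measured and on what is new or still open speak of the compounds shown alone.

Measured in an ADME assay on microsomes from liver (Rattus norvegicus) for metabolic stability; on this read-out lower numbers stand for a shorter-lived compound and higher numbers for a longer-lived compound:
- Compound 1 `CC(C)C(/C=C1\NC(=O)NC1=O)c1ccc(-c2ccc3cccc(F)c3c2)[nH]c1=O`: 1.46 h
- Compound 2 `C/C(=C1/OC(=O)NC1=O)C(c1ccc(-c2ccc3cccc(F)c3c2)[nH]c1=O)C(C)C`: > 3 h (a limit of the assay, not a number)
- Compound 3 `CC(C)C(CC1NC(=O)NC1=O)c1ccc(-c2ccc3cccc(F)c3c2)[nH]c1=O`: 0.35 h

Compound 3 gives the lowest result of the series, 0.35 h, and its steps to both other compounds lie beyond the scatter. Compound 4 `CC(C)C(c1ccc(-c2ccc3cccc(F)c3c2)[nH]c1=O)C1C(=O)NC(=O)N1C` has the same atoms as compound 3, joined differently: 3-methyl-2,5-dioxoimidazolidin-4-yl in place of (2,5-dioxoimidazolidin-4-yl)methyl on a saturated chain carbon bound to an aromatic carbon and a saturated chain carbon.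

Within the data shown here, no measured step makes this exact change. The closest evidence comes from the three steps that alter the group on the same saturated chain carbon. These are a 4.2-fold lower number from compound 1 to compound 3 (0.62 log units; beyond the scatter), an at least 8.5-fold lower number from compound 2 to compound 3 (0.93 log units; beyond the scatter) and an at least 2.0-fold higher number from compound 1 to compound 2 (0.31 log units; beyond the scatter). All three show that this assay responds to changes at this place. Among the measured compounds shown here, both other groups measured there give longer half-lives than the group in compound 3, although this rests on only two comparisons, and one of them involves a limit. Compound 3 therefore sits at the low end of the measured range, and a further change at this place is expected to move the number upward rather than downward. The size is expected to be no larger than the smaller measured step, a 4.2-fold lower number from compound 1 to compound 3 (0.62 log units; beyond the scatter).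

The expected step is a 2.3-fold higher number from compound 3 to compound 4 (0.36 log units; beyond the scatter), and a result within the scatter would not be surprising. For compound 4 the estimated half-life is 0.8 h, with an expected range from 0.3 h to 2.2 h.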

Compound 4, half-life: 0.263 h
The estimate for compound 4 lay 3.0-fold (0.48 log units) above the measured number; the measured number lies below the stated range.
By their numbers in this assay, from the lowest: compounds 4 and 3 (each within the scatter of the next); then compound 1. At a limit, above all of these: compound 2.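

In this assay, the swap of (2,5-dioxoimidazolidin-4-yl)methyl for 3-methyl-2,5-dioxoimidazolidin-4-yl on this saturated chain carbon does not separate the two groups: a 1.3-fold lower number from compound 3 to compound 4 (0.12 log units; within the scatter). Among these compounds, this is the first change at this place that the read-out does not resolve, so the position does not respond to every rearrangement of these atoms, and the two groups without a carbon-carbon double bond in the chain stand together, clear of the unsaturated group of compound 1: a 5.6-fold lower number from compound 1 to compound 4 (0.74 log units; beyond the scatter). The widest gap, an at least 11-fold lower number from compound 2 to compound 4 (1.05 log units; beyond the scatter), rests on a limit of the assay and not on a number: the limit of > 3 h in this assay, at which 1 of the 4 values shown sits.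

As far as these compounds go, the true half-life of compound 2 therefore stays unknown, and with it the full span of this position in this assay. From the compounds shown here alone, it also remains open whether an amine, a carboxylic acid or a longer chain on this saturated chain carbon would fall with compound 3 and compound 4 or would reach the level of compound 1.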